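Thiosemicarbazone series: terminal nitrogen substitution and antiproliferative potency

The compounds below may be only part of what the source reports. "The series", "measured", "known", "first", "only" and "open" are said of these compounds alone.

Measured compounds:
compound 1 `CN(C)C(=S)N/N=C/c1ccc2ccccc2n1`: 90 nM
compound 2 `NC(=S)N/N=C/c1cc2ccccc2s1`: 6770 nM
compound 3 `NC(=S)N/N=C/c1ccc2ccccc2n1`: 960 nM

The three compounds were run in a functional assay on HeLa cells (Homo sapiens) for antiproliferative activity, read by sulforhodamine B assay, with a stated time of 72 h; a lower number here means a stronger inhibitor, a higher number a weaker inhibitor. Compound 3 stands second highest of the three numbers: compound 2 sits higher by a margin beyond the scatter, and compound 1 sits lower by a margin also beyond the scatter. Going by the values given here, compound 2 carries a different core from compounds 1 and 3, and no single-point step links it to either of them, so its value is noted only as the highest of the three.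

The next compound, compound 4 `Fc1cccc(NC(=S)N/N=C/c2ccc3ccccc3n2)c1`, is not yet measured. It differs from compound 3 in one place: 3-fluorophenyl in place of hydrogen on an amide-type nitrogen.

Among the compounds with values here, only one measured step bears on this change, and it is not an exact match. The step of an 11-fold higher number from compound 1 to compound 3 (1.03 log units; beyond the scatter) shows that the unsubstituted terminal nitrogen gives a markedly higher number than the dimethylated one. Going from compound 3 to compound 4 adds a substituent to that same nitrogen, though an aromatic one in place of two methyls, so the step is expected to run downward in this assay, plausibly by a large margin, with the size uncertain. For compound 4 the expected step is a 3.8-fold lower number from compound 3 to compound 4 (0.58 log units; beyond the scatter), giving an estimate of 250 nM with a range from 60 nM to 1200 nM.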

Compound 4, half-maximal inhibitory concentration: 70100 nM
Compound 4: middle estimate off by 280-fold (2.45 log units), on the low side; measured number outside the range, above it.
By their numbers in this assay, from the lowest: compound 1; then compound 3; then compound 2; then compound 4.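

In this assay the change to 3-fluorophenyl in place of hydrogen on the amide-type nitrogen gives a 73-fold higher number from compound 3 to compound 4 (1.86 log units; beyond the scatter), so this nitrogen is not a place where any added substituent lowers the number. Set against an 11-fold higher number from compound 1 to compound 3 (1.03 log units; beyond the scatter), which places the dimethylamino compound below the unsubstituted one, the two results run in opposite directions, and both steps are large: what sits on this nitrogen matters, not merely whether the hydrogen is replaced. Nothing available here accounts for this difference between the two substituents.

The compounds shown leave open whether the rise belongs to the aromatic ring itself or to its fluorine, a question that a plain phenyl on the same nitrogen would address, while a single methyl would separate the effect of one small substituent from that of the two methyls in compound 1. Also open, on these data alone, is whether a benzyl group, with one carbon placed between the nitrogen and the ring, or a ring amine such as morpholine at this position would fall nearer compound 1 or compound 4.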